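The source may hold more compounds than are shown below. What is called first, only, known or untested is meant among the compounds shown, and "the series" means these compounds.

Measured so far, in an ADME assay on HEK293 cells (Homo sapiens) for cytotoxicity, read by ATP content, with a stated time of 6 h; a lower number here means that less compound is tolerated, a higher number that more compound is tolerated:

Compound 1 `CCCCNc1nc(N)nc2ccn(Cc3cccc(C)n3)c12` gives > 24000 nM, which is a limit of the assay and not a number.
Compound 2 `CCCCNc1nc(N)nc2ccn(Cc3ncccc3OC)c12` gives > 24000 nM, again a limit of the assay.
Compound 3 `Cc1nc(CNc2nc(N)nc3ccn(Cc4ccccn4)c23)cs1` gives > 24000 nM, also a limit of the assay.

Compound 3 therefore stands where every measured compound stands: at the limit (the limit of > 24000 nM in this assay, at which 3 of the 3 values shown sit). Nothing in the data separates it from compound 1 or compound 2, since none of the three received a number.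

Going by the values given here, only one pair of measured compounds differs in a single place, and that step, a step that the two limits leave unreadable from compound 1 to compound 2, cannot be read, as both of its values are limits. It concerns a group on a saturated chain carbon bound to an aromatic nitrogen, not the part of the core that changes next.

Compound 4 `Cc1cnc(COc2nc(N)nc3ccn(Cc4ccccn4)c23)o1` is the compound still to be measured. It differs from compound 3 by (5-methyl-1,3-oxazol-2-yl)methoxy in place of ((2-methyl-1,3-thiazol-4-yl)methyl)amino on an aromatic carbon. Among the compounds with values here, no measured step touches this position or exchanges a group of this kind, so there is no measured step that bears on the change, and no size or direction can be taken from the data beyond what the three limits show.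

The expectation for compound 4 in this assay is, accordingly, that it also reaches the limit, with an estimated value of 30000 nM, lying between 10000 nM and 100000 nM. That estimate corresponds to an expected step that the limit leaves unreadable from compound 3 to compound 4, which is within the scatter of repeated measurements.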

Compound 4, half-maximal cytotoxic concentration: > 24000 nM
Compound 4 ended at the assay's limit; the forecaster's own chance of this, stated with the estimate: 80%; the middle value does not contradict the limit.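

The step from compound 3 to compound 4 cannot be read, because both values are limits of the assay and not numbers: the limit of > 24000 nM in this assay, at which 4 of the 4 values shown sit.

The compounds shown leave open what concentration of any of these four compounds would harm the cells, and whether exchanging these groups changes it.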